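The compounds below may be only part of what the source reports. "The series", "measured", "known", "first", "only" and "open" are said of these compounds alone.

Working notes on the series, which shares the core of compound 1 `Cn1c(=O)c(=O)n(C2CCCC2)c2nc(N/N=C/c3ccccc3)ncc21` and varies the group on a carbon with a double bond to nitrogen. In a functional assay on A549 cells (Homo sapiens) for antiproliferative activity, read by MTT assay (on this read-out lower numbers stand for stronger inhibition and higher numbers for weaker inhibition), compound 1 gives > 100000 nM, which is a limit of the assay and not a number. In this assay, compound 2 `Cn1c(=O)c(=O)n(C2CCCC2)c2nc(N/N=C/c3ccc(F)c(Cl)c3)ncc21` gives 9410 nM and compound 3 `Cn1c(=O)c(=O)n(C2CCCC2)c2nc(N/N=C/c3ccc(O)c(F)c3)ncc21` gives 97800 nM. Compound 3 therefore has the higher of the two actual numbers, with a 10-fold higher number from compound 2 to compound 3 (1.02 log units; beyond the scatter).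

The next change is 3-methoxyphenyl in place of 3-fluoro-4-hydroxyphenyl on a carbon with a double bond to nitrogen, which leads to compound 4 `COc1cccc(/C=N/Nc2ncc3c(n2)n(C2CCCC2)c(=O)c(=O)n3C)c1`: 3-methoxyphenyl in place of 3-fluoro-4-hydroxyphenyl on a carbon with a double bond to nitrogen.

Two measured departures from phenyl bear on this change. One is large, an at least 10-fold lower number from compound 1 to compound 2 (1.02 log units; beyond the scatter), and came with 3-chloro-4-fluorophenyl. The other, an at least 1.0-fold lower number from compound 1 to compound 3 (0.00 log units; that floor lies within the scatter), has a floor within the scatter. Compound 4 carries neither group, and the large drop so far belongs to compound 2 alone, so one large drop is thin support for a second. No step beyond the scatter is therefore expected in this assay, with any drift more likely toward lower numbers. The estimated step is a 2.0-fold lower number from compound 3 to compound 4 (0.29 log units; within the scatter). Compound 4 is estimated at 50000 nM, with an expected range of 15000 nM to 100000 nM.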

Compound 4, half-maximal inhibitory concentration: 27400 nM
Beside the measured number, compound 4's estimate is 1.8-fold (0.26 log units) above it; the range from low to high includes it.
By their numbers in this assay, from the lowest: compound 2; then compound 4; then compound 3. At a limit, above all of these: compound 1.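

Going by these compounds alone, with 3-methoxyphenyl on the carbon with a double bond to nitrogen, this assay shows an at least 3.6-fold lower number from compound 1 to compound 4 (0.56 log units; beyond the scatter), so a step from phenyl that is beyond the scatter no longer belongs to 3-chloro-4-fluorophenyl alone, although compound 3 still gives no such step. Replacing 3-fluoro-4-hydroxyphenyl with 3-methoxyphenyl gives a 3.6-fold lower number from compound 3 to compound 4 (0.55 log units; beyond the scatter), while replacing 3-chloro-4-fluorophenyl with the same group gives a 2.9-fold higher number from compound 2 to compound 4 (0.46 log units; beyond the scatter), so the three substituted phenyl groups now separate at this position, with 3-chloro-4-fluorophenyl still giving the lowest number. The step from phenyl can be read only as a floor, because compound 1 stands at a limit of the assay and has no actual number: the limit of > 100000 nM in this assay, at which 1 of the 4 values shown sits.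

As far as these compounds go, the step to compound 4 removes fluorine and hydroxy and adds methoxy in a single change, so the contribution of each remains open. Also open, from the compounds shown here alone, is whether an amine or a carboxylic acid on the phenyl ring, or a longer alkyl chain in place of that ring, would match or improve on compound 2 at 9410 nM.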